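Swapping Hydroxymethyl for 2-Chloroethenyl in a Cell Assay

The source may hold more compounds than are shown below. What is called first, only, known or untested is meant among the compounds shown, and "the series" means these compounds.

Compound 1, `CC1(C)[C@@H](Cn2ccc(=O)[nH]c2=O)CC[C@@]1(C)CO`: > 200000 nM
Compound 2, `O=c1[nH]c(=O)n([C@H]2C[C@H](O)[C@@H](CO)O2)cc1CO`: 9180 nM
Compound 3, `CC(=O)OCCOCn1cnc2c(Cl)ncnc21`: 163000 nM

Of the compounds shown here, three have been tested in an ADME assay on L1210/0 cells (Mus musculus) for cytotoxicity, with a stated time of 48 h; on this read-out higher numbers stand for weaker inhibition and lower numbers for stronger inhibition. Compound 1 gives > 200000 nM, which is a limit of the assay rather than a number; this is the limit of > 200000 nM in this assay, at which 1 of the 3 values shown sits. Of the two numbers that remain, compound 2 has the lowest, and compound 3 gives the nearest number, a gap that lies beyond the usual scatter of repeated measurements. For the measured compounds named here, none of the three measured compounds differ from one another in a single place, so no measured step is available to calibrate the change at hand.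

Compound 4, `O=c1[nH]c(=O)n([C@H]2C[C@H](O)[C@@H](CO)O2)cc1/C=C/Cl`, has not yet been measured. It differs from compound 2 in one place: 2-chloroethenyl in place of hydroxymethyl on an aromatic carbon. Going by the values given here, with no measured step to lean on, the expectation is for a modest move toward weaker inhibition, of a size that may or may not clear the scatter. Compound 4 is therefore expected to give 30000 nM, with a likely range from 6000 nM to 150000 nM. The expected step of a 3.3-fold higher number from compound 2 to compound 4 (0.51 log units; beyond the scatter) is estimated to point toward higher numbers.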

Compound 4, half-maximal inhibitory concentration: > 200000 nM
Compound 4 ended at the assay's limit (the forecaster's own chance of this, stated with the estimate: 10%); middle value at least 6.6-fold (0.82 log units) away from the limit.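

Putting 2-chloroethenyl in place of hydroxymethyl on this aromatic carbon gives an at least 21-fold higher number from compound 2 to compound 4 (1.33 log units; beyond the scatter) in this assay. For the compounds shown here, this is the first single-place comparison, and it shows that this one position can strongly change the read-out while the rest of compound 2 stays the same. The value of compound 4 is a limit of the assay and not a number: the limit of > 200000 nM in this assay, at which 2 of the 4 values shown sit.

The two groups differ at once in size, in the chlorine, in the double bond and in the hydrogen-bond donor, so the compounds shown do not separate these features. From the compounds shown here alone, whether a plain methyl, an aminomethyl or a saturated 2-chloroethyl at this carbon would stay close to compound 2 remains open, as does whether the same swap acts alike on another core.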